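The source may report more compounds than this note shows. Statements on the series, on what has been measured and on what is new or still open speak of the compounds shown alone.

In a functional assay on the whole organism for inhibition, with Brassica rapa subsp. chinensis as the target, with a stated time of 3 days, tested at 100 ppm (a lower number here means less inhibition of growth, a higher number more inhibition of growth at the concentration tested), compound 2 `CCCCCNC(=O)/C=C/c1ccccc1` gives 60%, compound 3 `CCCCCCCCCCNC(=O)/C=C/c1ccccc1` gives 10% and compound 1 `CCCCCCCCCCCCCCCCNC(=O)/C=C/c1ccccc1` gives 20%. Compound 3 thus sits level with compound 1 and far from compound 2. Compound 4 `CCCCCCCCCCCCNC(=O)/C=C/c1ccccc1` lengthens the chain of compound 3: ethyl in place of hydrogen on a saturated chain carbon, ten or more bonds along the chain from an amide-type nitrogen. Within the data shown here, two measured steps bear on this. The large one, a number 50 percentage points lower from compound 2 to compound 3 (beyond the scatter), changes the chain five bonds along from an amide-type nitrogen. The other, a number 10 percentage points lower from compound 1 to compound 3 (within the scatter), changes it at the same place as in compound 4, and on that ground no shift beyond the scatter is expected in this assay. The estimated step is a number 5 percentage points higher from compound 3 to compound 4 (within the scatter). Compound 4 is expected at 15%, within a range of 0% to 30%.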

Compound 4, percent growth inhibition at one concentration: 48%
The estimate for compound 4 lay 33 percentage points below the measured number, and the stated range ends below it.
By their numbers in this assay, from the lowest: compounds 3 and 1 (each within the scatter of the next); then compound 4; then compound 2.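

In this assay, ethyl in place of hydrogen on a saturated chain carbon, ten or more bonds along the chain from an amide-type nitrogen, gives a number 38 percentage points higher from compound 3 to compound 4 (beyond the scatter), so a change this far out can matter. The other two steps are a number 12 percentage points lower from compound 2 to compound 4 (beyond the scatter) and a number 28 percentage points higher from compound 1 to compound 4 (beyond the scatter), so the numbers do not fall steadily as the chain lengthens, and compound 4 goes against any such trend. Nothing available explains this rise.

From the compounds shown here alone, whether an amine or a carboxylic acid at this place would keep the higher number stays open. So does how a propyl group in place of the ethyl would read.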